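This account rests on a few compounds, and the source may have more. Where it says the series, first, only, none or still open, it means among the compounds named here.

Compound 1 `COc1ccc(CN(C(=O)CSC(=S)N2CCN(C(C)=O)CC2)c2cc(OC)c(OC)c(OC)c2)cc1`: 1370 nM
Compound 2 `COc1ccc(CN(C(=O)CSC(=S)N2CCN(Cc3ccc(C(C)(C)C)cc3)CC2)c2cc(OC)c(OC)c(OC)c2)cc1`: 6890 nM

Both values come from a functional assay on HCT-116 cells (Homo sapiens) for inhibition, read by CCK-8 assay, with a stated time of 48 h; a lower number here means a stronger inhibitor, a higher number a weaker inhibitor. Among the compounds with values here, compound 1 has the lower of the two numbers, with compound 2 as its only neighbour. Compound 3 `COc1ccc(CN(C(=O)CN2CCN(C(C)=O)CC2)c2cc(OC)c(OC)c(OC)c2)cc1` is the next to be read, and its change from compound 1 is a group of 9 heavy atoms (6 carbon, 2 nitrogen, 1 oxygen; one six-membered non-aromatic ring with 2 hetero atoms) in place of a group of 12 heavy atoms (7 carbon, 2 nitrogen, 1 oxygen, 2 sulfur; one six-membered non-aromatic ring with 2 hetero atoms), on a saturated chain carbon bound to a carbonyl carbon. Within the data shown here, the one measured step, a 5.0-fold higher number from compound 1 to compound 2 (0.70 log units; beyond the scatter), concerns an amine nitrogen in a ring and not the saturated chain carbon bound to a carbonyl carbon, so it bears only loosely on this change. Among the measured compounds shown here, it gives a rough scale for a modest step, and no measured step shows the effect of this change. With compound 1 holding the lower number, a modest rise is expected, though a result within the scatter remains possible. The expected step is a 2.2-fold higher number from compound 1 to compound 3 (0.34 log units; beyond the scatter). Compound 3 is estimated at 3000 nM, with an expected range of 800 nM to 12000 nM.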

Compound 3, half-maximal inhibitory concentration: > 20000 nM
Compound 3: only a limit was reported; the forecaster's own chance of this, stated with the estimate: 10%; at least 6.6-fold (0.82 log units) between middle value and limit.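

In this assay, putting 4-acetylpiperazin-1-yl on the saturated chain carbon bound to a carbonyl carbon gives an at least 14-fold higher number from compound 1 to compound 3 (1.16 log units; beyond the scatter), so this position is sensitive to the change, whereas the earlier step touched only an amine nitrogen in a ring. The group that leaves holds 2 sulfur atoms and the group that enters holds none. Compound 3 gives only a limit, not a number: the limit of > 20000 nM in this assay, at which 1 of the 3 values shown sits.

Which part of the leaving group matters remains open. A simple thioether, or a carbonyl in place of the carbon-sulfur double bond, would separate the contribution of each sulfur atom.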